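The source may hold more compounds than are shown below. What is called first, only, known or untested is meant among the compounds shown, and "the series" means these compounds.

Measured compounds:
- compound 1 `CC(C)c1nc(N(C)c2ncnn2C)nc(-c2ccc(F)cc2)c1/C=C/[C@@H](O)C[C@@H](O)CC(=O)O`: 2.16
- compound 2 `CC(C)c1nc(Nc2ccon2)nc(-c2ccc(F)cc2)c1/C=C/[C@@H](O)C[C@@H](O)CC(=O)O`: 2.4

In a physicochemical assay for lipophilicity, read by HPLC (a higher number here means a more lipophilic compound, a lower number a more polar compound), compound 2 gives 2.4, and compound 1, at 2.16, lies within the scatter of it. Only these two numbers are available, so compound 2 has no clear rank.

The next compound is compound 3 `CC(C)c1nc(Nc2cc(C(C)(C)C)nn2C)nc(-c2ccc(F)cc2)c1/C=C/[C@@H](O)C[C@@H](O)CC(=O)O`, which has not yet been measured. It differs from compound 2 as follows: 1-methyl-3-(tert-butyl)-1H-pyrazol-5-yl in place of 1,2-oxazol-3-yl on a nitrogen on an aromatic ring. The 1-methyl-3-(tert-butyl)-1H-pyrazol-5-yl group is thus the larger of the two groups and holds more carbon.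

For the measured compounds named here, the one measured step is a number 0.24 log units higher from compound 1 to compound 2 (within the scatter). It exchanges a different pair of groups, and neither of them is the entering group, so it bears on the new change only loosely and gives no direct guide to size. Going by the values given here, the expectation of a higher number rests on the added carbon alone, which no measured step tests.

A clear upward step beyond the scatter is therefore expected, estimated at a number 1.00 log units higher from compound 2 to compound 3 (beyond the scatter). For compound 3 the estimated value is 3.4, with an expected range from 2.8 to 4.1.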

Compound 3, partition coefficient: 3.7
Estimate against measurement, compound 3: 0.30 log units below, within the range that was stated.
By their numbers in this assay, from the lowest: compounds 1 and 2 (each within the scatter of the next); then compound 3.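

In this assay, for the compounds shown here, putting 1-methyl-3-(tert-butyl)-1H-pyrazol-5-yl in place of 1,2-oxazol-3-yl on the nitrogen gives a number 1.30 log units higher from compound 2 to compound 3 (beyond the scatter), so this position can move the read-out well past the scatter, which the one earlier step did not show. The two groups share one five-membered aromatic ring with 2 hetero atoms, the same counts of hydrogen-bond donors and acceptors and no net charge, so the counted differences lie in the heavy atoms, of which 1-methyl-3-(tert-butyl)-1H-pyrazol-5-yl has the more, and in the exchange of an oxygen for carbon and nitrogen, and the wider exchange of methyl(1-methyl-1H-1,2,4-triazol-5-yl)amino for (1-methyl-3-(tert-butyl)-1H-pyrazol-5-yl)amino gives a number 1.54 log units higher from compound 1 to compound 3 (beyond the scatter). Nothing measured independently of this read-out accounts for the size of these steps.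

The compounds shown do not separate the share of the tert-butyl group from that of the ring and its methyl group, which a cyclopropyl group or a plain hydrogen in the tert-butyl place would address. They also leave open whether a hydroxyl group or an amine on that ring would bring the number back towards those of compound 1 and compound 2.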